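Bromo Substitution Across Two Chalcone Amide Cores

A few compounds are considered here, and "the series" means these few. Any claim that something is new, unique, unknown or untested is made for them only; others in the source may bear on it.

Compound 1 `O=C(CCl)Nc1ccc(C(=O)/C=C/c2ccccc2)cc1`: 12600 nM
Compound 2 `O=C(CCl)Nc1ccc(C(=O)/C=C/c2ccc(Br)cc2)cc1`: 13300 nM
Compound 3 `O=C(CSC(=S)N[C@H]1CCOC1=O)Nc1ccc(C(=O)/C=C/c2ccccc2)cc1`, for which only a limit of the assay is known: > 128000 nM

In a functional assay on SMMC-7721 cells (Homo sapiens) for cytotoxicity, read by MTT assay, with a stated time of 72 h (on this read-out lower numbers stand for stronger inhibition and higher numbers for weaker inhibition), compound 1 and compound 2 share a core and differ only by bromo in place of hydrogen on an aromatic carbon. That change gave a 1.1-fold higher number from compound 1 to compound 2 (0.02 log units; within the scatter).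

Compound 3 differs from compound 1 in its core by a group of 10 heavy atoms (5 carbon, 1 nitrogen, 2 oxygen, 2 sulfur; one five-membered non-aromatic ring with 1 hetero atom) in place of one chlorine atom, on a saturated chain carbon bound to a carbonyl carbon. This change gave an at least 10-fold higher number from compound 1 to compound 3 (1.00 log units; beyond the scatter). The value of compound 3 is a limit of the assay and not a number, (the limit of > 128000 nM in this assay, at which 1 of the 3 values shown sits).

Compound 4 `O=C(CSC(=S)N[C@H]1CCOC1=O)Nc1ccc(C(=O)/C=C/c2ccc(Br)cc2)cc1` has not yet been measured in this assay. It differs from compound 3 by bromo in place of hydrogen on an aromatic carbon, the same change that separates compound 1 from compound 2, made at the same kind of place on the other core.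

The expectation rests on the earlier step, which was a 1.1-fold higher number from compound 1 to compound 2 (0.02 log units; within the scatter). Compound 4 is therefore expected to remain at the limit, with an estimated step that the limit leaves unreadable from compound 3 to compound 4. Compound 4 is estimated at 160000 nM, between 90000 nM and 320000 nM.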

Compound 4, half-maximal inhibitory concentration: 18000 nM
Beside the measured number, compound 4's estimate is 8.9-fold (0.95 log units) above it, outside the stated range (below it).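

In this assay, bromo in place of hydrogen on an aromatic carbon gave an at least 7.1-fold lower number from compound 3 to compound 4 (0.85 log units; beyond the scatter) on the core of compound 3, so the change did not carry over unaltered from the core of compound 1: the same change on two cores in this assay, a 1.1-fold higher number (0.02 log units; within the scatter) from compound 1 to compound 2 and an at least 7.1-fold lower number (0.85 log units; beyond the scatter) from compound 3 to compound 4, at least 7.5-fold (0.87 log units) apart, beyond the scatter of two such steps. Read the other way, the group that replaces the chlorine gave a 1.4-fold higher number from compound 2 to compound 4 (0.13 log units; within the scatter) once the 4-bromophenyl was present, and this too differs from the step without bromo: the same change on two cores in this assay, an at least 10-fold higher number (1.00 log units; beyond the scatter) from compound 1 to compound 3 and a 1.4-fold higher number (0.13 log units; within the scatter) from compound 2 to compound 4, at least 7.5-fold (0.87 log units) apart, beyond the scatter of two such steps. Compound 3 is known only as a limit of the assay (> 128000 nM), which leaves the true size of its step to compound 4 unread, and these four compounds show that the result of the change depends on the core without showing why.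

On these data alone, it remains open whether a chloro or methoxy group in place of the bromo would behave in the same way on both cores. As far as these compounds go, it is equally open whether an amine or a longer chain in place of the chlorine would show the same dependence.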